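The source may hold more compounds than are shown below. What is called first, only, known or untested is meant among the compounds shown, and "the series" means these compounds.

Measured compounds:
compound 1 `CCN(CC)S(=O)(=O)c1ccc(S(=O)(=O)N2CCC[C@@H](C(=O)N3CCOCC3)C2)cc1` — 350 nM
compound 2 `CCN(CC)S(=O)(=O)c1ccc(S(=O)(=O)N2CCC[C@@H](C(=O)N3CCC(C(F)(F)F)CC3)C2)cc1` — 320 nM

In a functional assay on MIA PaCa-2 cells (Homo sapiens) for inhibition, read by MTT assay, with a stated time of 7 days (a higher number here means a weaker inhibitor, a lower number a stronger inhibitor), compound 2 gives 320 nM, and compound 1 gives 350 nM; the two stand within the scatter of each other, as the step of a 1.1-fold lower number from compound 1 to compound 2 (0.04 log units; within the scatter) shows. Compound 3 `CCN(CC)S(=O)(=O)c1ccc(S(=O)(=O)N2CCC[C@@H](C(=O)N3CCC(COC)CC3)C2)cc1` differs from compound 2 by methoxymethyl in place of trifluoromethyl on a saturated ring carbon. Within the data shown here, the one measured step that bears on this position, a 1.1-fold lower number from compound 1 to compound 2 (0.04 log units; within the scatter), left the number essentially unchanged, so a step of no more than the scatter is expected in this assay, in either direction. Compound 3 is therefore estimated at 330 nM, within 150 nM to 750 nM, an expected step of a 1.0-fold higher number from compound 2 to compound 3 (0.01 log units; within the scatter).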

Compound 3, half-maximal inhibitory concentration: 250 nM
Compound 3: middle estimate off by 1.3-fold (0.12 log units), on the high side; the range from low to high includes it.
By their numbers in this assay, from the lowest: compounds 3, 2 and 1 (each within the scatter of the next).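

In this assay methoxymethyl, which carries a hydrogen-bond acceptor where trifluoromethyl has none, stays within the scatter of trifluoromethyl on this saturated ring carbon (a 1.3-fold lower number from compound 2 to compound 3 (0.11 log units; within the scatter)). The 4-(methoxymethyl)piperidin-1-yl amide also stays within the scatter of the morpholin-4-yl amide (a 1.4-fold lower number from compound 1 to compound 3 (0.15 log units; within the scatter)), so all three groups on the carbonyl carbon read alike so far. Nothing measured here offers an explanation for this flatness. The compounds shown leave open whether a group of another kind at this ring carbon, such as an amine, a carboxylic acid or a longer chain, would move the number beyond the scatter.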